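The source may report more compounds than this note shows. Statements on the series, on what has been measured and on what is new or still open speak of the compounds shown alone.

Compound 1 `COc1cc(C2=CC3CC(C2)CN(C)C3)cnc1Cl` in an in vitro assay on SH-EP1 cells for displacement of a labelled ligand from Neuronal acetylcholine receptor; alpha4/beta2 (Homo sapiens) (on this read-out higher numbers stand for weaker inhibition and lower numbers for stronger inhibition), gives 4.4 nM. Compound 2 `CN1CC2C=C(c3ccc(F)nc3)CC(C2)C1` gives 18 nM. Compound 3 `COc1ccc(C2=CC3CC(C2)CN(C)C3)cn1` gives 797 nM.

Compound 3 stands at the highest number of the three: compound 2 sits well below it, and compound 1 is further away still, the widest gap among the measured compounds.

The unmeasured compound 4 `CN1CC2C=C(c3ccc(Cl)nc3)CC(C2)C1` differs from compound 3 in one place: chloro in place of methoxy on an aromatic carbon. Among the measured compounds shown here, one measured step bears on this change, the one in the other direction, where a methoxy group came in for a fluoro group on an aromatic carbon of the same ring position; that gave a 44-fold higher number from compound 2 to compound 3 (1.65 log units; beyond the scatter). Returning from methoxy to a halogen should therefore undo most of that rise, and the chloro-bearing compound 1, with its low value, is in line with a halogen at that position being tolerated well, though it carries a second substituent and no step to it is counted.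

Compound 4 is therefore expected to give a much lower number than compound 3, a step of a 66-fold lower number from compound 3 to compound 4 (1.82 log units; beyond the scatter) in this assay. The estimate for compound 4 is 12 nM, with a range from 3 nM to 45 nM.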

Compound 4, inhibition constant: 22 nM
The estimate for compound 4 lay 1.8-fold (0.26 log units) below the measured number, and the stated range covers the measured number.
By their numbers in this assay, from the lowest: compound 1; then compounds 2 and 4 (each within the scatter of the next); then compound 3.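

In this assay the swap from methoxy to chloro on the carbon next to the ring nitrogen is large, a 36-fold lower number from compound 3 to compound 4 (1.56 log units; beyond the scatter), while chloro and fluoro at this place cannot be told apart, with a 1.2-fold higher number from compound 2 to compound 4 (0.09 log units; within the scatter); two different halogens thus sit at much the same level, and compound 3 with its methoxy group is the one that stands apart. A methoxy group does not go with a higher number everywhere on the ring: with chloro held in place, hydrogen in place of the further methoxy group of compound 1 gives a 5.0-fold higher number from compound 1 to compound 4 (0.70 log units; beyond the scatter), so in that other place the methoxy group goes with the lower number. Nothing available here accounts for either of these differences.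

The compounds shown leave open whether the high number of compound 3 is particular to methoxy or would also come with other groups on this carbon, such as an amine, a methyl group or a nitrile, and where hydrogen there would fall. They also leave open whether the further methoxy group would give a similar step alongside fluoro instead of chloro.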